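Pyrrolidinylpyridyl for cyanophenyl on the thiazole-acetic acid series

This account rests on a few compounds, and the source may have more. Where it says the series, first, only, none or still open, it means among the compounds named here.

Three compounds of the shared core have numbers in an in vitro functional assay on HEK285-7 cells for antagonist activity at prostaglandin D2 receptor 2 (Homo sapiens), read by BRET and beta-arrestin recruitment; a higher number here means a weaker inhibitor, a lower number a stronger inhibitor. Compound 1 `O=C(O)Cc1sc(C2COc3ccccc3O2)nc1-c1ccc(Cl)cc1` gives 2000 nM, compound 2 `COc1ccc(C(c2ccccc2)c2nc(-c3ccc(Cl)cc3)c(CC(=O)O)s2)cc1` gives 76 nM, and compound 3 `N#Cc1ccc(-c2nc(C(c3ccc(F)cc3)c3ccc(F)cc3)sc2CC(=O)O)cc1` gives 1500 nM. Compound 3 stands second highest of the three: its number and that of compound 1 lie within the scatter of each other, while compound 2 sits well below it, beyond the scatter.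

Compound 4 `O=C(O)Cc1sc(C(c2ccc(F)cc2)c2ccc(F)cc2)nc1-c1ccnc(N2CCCC2)c1` differs from compound 3 in one place: 2-(pyrrolidin-1-yl)pyridin-4-yl in place of 4-cyanophenyl on an aromatic carbon. For the measured compounds named here, no measured pair shows this change, so its size is unknown; a small step toward lower numbers, not clearly beyond the scatter, is expected in this assay. Compound 4 is estimated at 800 nM, with a range from 150 nM to 4000 nM, which would mean a step of a 1.9-fold lower number from compound 3 to compound 4 (0.27 log units; within the scatter).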

Compound 4, half-maximal inhibitory concentration: > 100000 nM
Compound 4: no number, only a limit; the forecaster's own chance of this, stated with the estimate: 5%; at least 120-fold (2.09 log units) between middle value and limit.
By their numbers in this assay, from the lowest: compound 2; then compounds 3 and 1 (each within the scatter of the next). At a limit, above all of these: compound 4.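

In this assay, compound 4 carries a limit, not a number: > 100000 nM. This position, on an aromatic carbon next to the ring nitrogen, does not tolerate every aromatic group: 2-(pyrrolidin-1-yl)pyridin-4-yl in place of 4-cyanophenyl gives an at least 66-fold higher number from compound 3 to compound 4 (1.82 log units; beyond the scatter). The full size of the step cannot be read from a limit: the limit of > 100000 nM in this assay, at which 1 of the 4 values shown sits.

The compounds shown do not separate the contribution of the pyrrolidine ring from that of the pyridine ring nitrogen. An unsubstituted pyridinyl group, or a phenyl group bearing pyrrolidin-1-yl, at this position would tell the two apart.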